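The compounds below may be only part of what the source reports. "The series", "measured", "known", "first", "only" and "open" are said of these compounds alone.

Compound 1 `O=C1N/C(=C\c2ccc(O)cc2)C(=O)N1c1ccc(I)cc1` gives 25500 nM in a functional assay on NCI-H292 cells (Homo sapiens) for antiproliferative activity; a higher number here means a weaker inhibitor, a lower number a stronger inhibitor. Compound 2 `O=C1N/C(=C\c2ccc(O)cc2)C(=O)N1c1ccc(Br)cc1` gives 69900 nM in this assay, the step of a 2.7-fold higher number from compound 1 to compound 2 (0.44 log units; beyond the scatter). Compound 3 `O=C(Nc1ccc(Cl)cc1)c1ccc(N2C(=O)N/C(=C\c3ccc(O)cc3)C2=O)cc1` reaches only a limit of this assay, > 200000 nM. The step of an at least 7.8-fold higher number from compound 1 to compound 3 (0.89 log units; beyond the scatter) and the step of an at least 2.8-fold higher number from compound 2 to compound 3 (0.45 log units; beyond the scatter) both end at the limit of > 200000 nM in this assay, at which 1 of the 3 values shown sits, so compound 3 stands at the high end of the three numbers shown, without a number of its own.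

Compound 4 `O=C(NCC1CCCCC1)c1ccc(N2C(=O)N/C(=C\c3ccc(O)cc3)C2=O)cc1` differs from compound 3 in one place: cyclohexylmethyl in place of 4-chlorophenyl on an amide-type nitrogen. For the measured compounds named here, no measured step bears directly on this exchange; the two steps into compound 3 concern only the arrival of the carbamoyl arm, and that arm is kept in compound 4. Going by the values given here, nothing among the measured compounds shows a gain once the arm is present. The number for compound 4 in this assay is therefore expected to stay at or near the limit, an estimated step of a number no higher from compound 3 to compound 4 (the limit leaves the size open). Compound 4 is estimated at 200000 nM, within a range from 80000 nM to 500000 nM.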

Compound 4, half-maximal inhibitory concentration: > 200000 nM
Compound 4: a limit, no number; the forecaster's own chance of this, stated with the estimate: 70%; the middle value lies on the limit itself.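

In this assay compound 4 gives > 200000 nM, a limit and not a number, so cyclohexylmethyl, with its non-aromatic ring, brings no readable recovery over 4-chlorophenyl on the amide-type nitrogen. The loss on replacing the halogen with a carbamoyl arm now holds for a second substituent on that nitrogen, with an at least 2.8-fold higher number from compound 2 to compound 4 (0.45 log units; beyond the scatter) and an at least 7.8-fold higher number from compound 1 to compound 4 (0.89 log units; beyond the scatter). The step between compound 3 and compound 4 cannot be read, as both stand at the limit: the limit of > 200000 nM in this assay, at which 2 of the 4 values shown sit.

On these data alone, how far either compound lies past the limit, and so any order between 4-chlorophenyl and cyclohexylmethyl, stays open. Also open, as far as these compounds go, is whether an amine or a carboxylic acid at the end of a chain on the amide-type nitrogen would bring the number back towards that of compound 1.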